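This account rests on a few compounds, and the source may have more. Where it says the series, first, only, none or still open, it means among the compounds named here.

Measured compounds:
compound 2 `CC(C)(C)OC(=O)N1CCC(c2coc3c(Nc4ccc(S(C)(=O)=O)cc4F)ncnc23)CC1`: 129 nM
compound 1 `CC(O)c1cnc(N2CCC(c3coc4c(N5CCc6cc(S(C)(=O)=O)ccc65)ncnc34)CC2)nc1`: 586 nM

Within the data shown here, in a functional assay on cells for agonist activity at Glucose-dependent insulinotropic receptor (Homo sapiens), read by a luciferase reporter, with a stated time of 4 h (on this read-out higher numbers stand for an effect only at larger amounts of compound and lower numbers for an effect already at smaller amounts), compound 2 gives the lowest of the two numbers; compound 1, the only other measured compound, sits at a higher number in this assay, and that gap is beyond the scatter. Among the measured compounds shown here, no single-point step between measured compounds is available, so the series offers no direct precedent for the change at hand.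

Compound 3 `CN(c1ccc(S(C)(=O)=O)cc1F)c1ncnc2c(C3CCN(C(=O)OC(C)(C)C)CC3)coc12` is not yet measured. It differs from compound 2 by methyl in place of hydrogen on a nitrogen on an aromatic ring. The hydrogen that leaves is a donor on the ring nitrogen joining the two aromatic parts; nothing in the measured pair shows what its removal does. The expectation is a step toward a higher number, beyond the scatter, of the size a 3.5-fold higher number from compound 2 to compound 3 (0.54 log units; beyond the scatter). Compound 3 is estimated at 450 nM, within a range from 110 nM to 2500 nM.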

Compound 3, half-maximal effective concentration: > 1000 nM
Compound 3 ended at the assay's limit; the forecaster's own chance of this, stated with the estimate: 10%; middle value at least 2.2-fold (0.34 log units) from the limit.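

In this assay, among these compounds, methyl in place of hydrogen on a nitrogen on an aromatic ring brings an at least 7.7-fold higher number from compound 2 to compound 3 (0.88 log units; beyond the scatter) and supplies the first single-place step, showing that this position does not tolerate the change without loss on this read-out. Compound 3 stands at > 1000 nM, which is a limit of the assay. The step therefore fixes a direction and a minimum size, but not the full size of the loss: the limit of > 1000 nM in this assay, at which 1 of the 3 values shown sits.

Still open, from the compounds shown here alone, is whether the loss is specific to methyl, or whether ethyl or acetyl on this nitrogen would give the same result. Also open, going by these compounds, is how an ether oxygen in place of this nitrogen, which would likewise carry no hydrogen, would read in this assay.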